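Thiourea series: methyl to isopropyl on the chain carbon

This account rests on a few compounds, and the source may have more. Where it says the series, first, only, none or still open, it means among the compounds named here.

Measured so far:
compound 1 `C[C@H](NC(=S)Nc1cc(C(F)(F)F)cc(C(F)(F)F)c1)c1nc2ccccc2[nH]1`, 220000 nM
compound 2 `CC(C)[C@@H](NC(=S)Nc1ccccc1)c1nc2ccccc2[nH]1`, 31500 nM

In a functional assay on A549 cells (Homo sapiens) for cytotoxicity, read by MTT assay (on this read-out higher numbers stand for weaker inhibition and lower numbers for stronger inhibition), compound 1 stands with the highest of the two numbers; compound 2 gives the lower one, and the gap between the two lies beyond the scatter. Within the data shown here, the two differ in more than one place, so no single step is defined between them.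

Compound 3 `CC(C)[C@H](NC(=S)Nc1cc(C(F)(F)F)cc(C(F)(F)F)c1)c1nc2ccccc2[nH]1` has not been measured. It differs from compound 1 by isopropyl in place of methyl on a saturated chain carbon bound to an amide-type nitrogen and an aromatic carbon. A step toward a lower number is expected, but of moderate size; the estimate for compound 3 is 100000 nM, within 30000 nM to 300000 nM, a step of a 2.2-fold lower number from compound 1 to compound 3 (0.34 log units; beyond the scatter).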

Compound 3, half-maximal inhibitory concentration: 25100 nM
Compound 3: the middle estimate sits 4.0-fold (0.60 log units) above what was measured; the measured number lies below the stated range.
By their numbers in this assay, from the lowest: compounds 3 and 2 (each within the scatter of the next); then compound 1.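

In this assay, isopropyl in place of methyl on a saturated chain carbon bound to an amide-type nitrogen and an aromatic carbon gives an 8.8-fold lower number from compound 1 to compound 3 (0.94 log units; beyond the scatter). Among these compounds, this is the first single-place step, and it shows that the number responds to the group at this carbon, which the earlier pair, differing in more than one place, could not show.

Going by these compounds, whether ethyl, cyclopropyl or a longer chain at this carbon would give a similar step remains open. No measurement shown gives a cause for this step.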